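The source may report more compounds than this note shows. Statements on the series, on what has been measured and on what is new or still open speak of the compounds shown alone.

In an ADME assay on cells (Hepatocyte, Homo sapiens) for metabolic stability, read by LC-MS, with a stated time of 90 min, tested at 1 uM (a higher number here means faster removal of the compound, a lower number slower removal), the three measured compounds stand as follows.
Compound 1 `CC(C)n1nc(-c2ccc3oc(N)nc3c2)c2c(N)nc(N)nc21` gives < 5 uL/min, a limit of the assay.
Compound 2 `CC(C)n1nc(-c2ccc3oc(N)nc3c2)c2c(=O)[nH]c(N)nc21` gives < 5 uL/min, also a limit.
Compound 3 `CNc1nc2c(c(-c3ccc4oc(N)nc4c3)nn2C(C)C)c(=O)[nH]1` gives < 5 uL/min, again a limit.

Compound 3 therefore stands at the floor of this assay, where all three values sit: the limit of < 5 uL/min in this assay, at which 3 of the 3 values shown sit. Among the measured compounds shown here, the only single-point step among the measured compounds, a step that the two limits leave unreadable from compound 2 to compound 3, is unreadable, both of its ends being limits. Compound 4 `CC(C)n1nc(-c2ccc3oc(N)nc3c2)c2c(=O)[nH]cnc21` differs from compound 3 by hydrogen in place of methylamino on an aromatic carbon. For the measured compounds named here, no measured step bears readably on this change, so no step beyond the scatter is expected in this assay in either direction, and compound 4 is expected to sit at the limit as well. The step expected is a step that the limit leaves unreadable from compound 3 to compound 4. Compound 4 is thus estimated at 3 uL/min, with a range from 1 uL/min to 9 uL/min.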

Compound 4, intrinsic clearance in a liver preparation (reported as CLH), per the amount of preparation that the assay uses in the Hepatocyte assay: < 5 uL/min
Compound 4 ended at the assay's limit; the forecaster's own chance of this, stated with the estimate: 75%; the middle value does not contradict the limit.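

In the Hepatocyte assay the steps among compound 2, compound 3 and compound 4 cannot be read, all their values being limits. In a physicochemical assay for solubility, read by HPLC, in phosphate buffer, measured as kinetic solubility, with a stated time of 24 h, at 20 degrees C, at pH 7.4, tested at 100 uM (on this read-out lower numbers stand for lower solubility and higher numbers for higher solubility), compound 3 gives < 1000 nM, a limit. In the physicochemical assay compound 4 gives 3000 nM. From the compounds shown here alone, how far these compounds differ in the Hepatocyte assay stays open, as does the actual solubility of compound 3.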